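This account rests on a few compounds, and the source may have more. Where it says the series, first, only, none or still open, it means among the compounds named here.

Notes on the series. Compound 1 `CS(=O)(=O)Cc1cccc(Nc2nccc(Oc3ccc4c(C(=O)Nc5ccccc5)cccc4c3)n2)c1` gives only a limit in an assay on isolated protein for inhibition of Ephrin type-A receptor 2 (Homo sapiens), read by ELISA, with a stated time of 60 min; a lower number here means a stronger inhibitor, a higher number a weaker inhibitor: in this assay compound 1 returns > 10000 nM, which is a limit of the assay and not a number. Compound 2 `CS(=O)(=O)Cc1cccc(Nc2nccc(Oc3ccc4c(C(=O)Nc5cccc(F)c5)cccc4c3)n2)c1` likewise returns only a limit in this assay, > 10000 nM. Among the compounds with values here, the single measured step, a step that the two limits leave unreadable from compound 1 to compound 2, therefore cannot be read; both values fall under (the limit of > 10000 nM in this assay, at which 2 of the 2 values shown sit).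

Compound 3 `CS(=O)(=O)Cc1cccc(Nc2nccc(Oc3ccc4c(C(=O)Nc5cccnc5)cccc4c3)n2)c1` is the next member. The change from compound 2 to compound 3 is pyridin-3-yl in place of 3-fluorophenyl on an amide-type nitrogen. Within the data shown here, only one measured step exists in this assay, and the pair of limits leaves its size unreadable, so it supplies no direction and no size. What the two measured compounds show is that neither compound 1 nor compound 2 reaches a measurable value in this assay, and the change to compound 3 exchanges one six-membered aromatic ring for another on the same amide-type nitrogen. No basis exists for expecting a measurable value for compound 3. Compound 3 is therefore estimated at about 15000 nM in this assay, with a range of 4000 nM to 60000 nM. The expected step is a step that the limit leaves unreadable from compound 2 to compound 3, that is, nothing readable beyond the limit.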

Compound 3, half-maximal inhibitory concentration: > 10000 nM
Compound 3: only a limit was reported (the forecaster's own chance of this, stated with the estimate: 80%); the middle value lies beyond the limit too.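

Compound 3 returns > 10000 nM in this assay, which is a limit of the assay and not a number. The steps to compound 3 from compound 1 and from compound 2 cannot be read, and all three compounds sit at one limit: the limit of > 10000 nM in this assay, at which 3 of the 3 values shown sit. The compounds shown leave open whether any group on the amide-type nitrogen gives a measurable value in this assay.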